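The compounds below may be only part of what the source reports. "The series", "measured", "known", "first", "only" and "open" are said of these compounds alone.

Three compounds have so far been measured in an assay for binding affinity to protein lin-28 homolog A (Mus musculus), with a stated time of 1 h; a higher number here means a weaker inhibitor, a lower number a stronger inhibitor:

compound 1, `O=S(=O)(Nc1ccccc1NS(=O)(=O)c1ccc(Cl)cc1)c1ccc(Cl)cc1`, gives 27500 nM
compound 2, `Cc1ccc(NS(=O)(=O)c2ccc(Cl)cc2)c(NS(=O)(=O)c2ccc(Cl)cc2)c1`, gives 28400 nM
compound 3, `O=S(=O)(Nc1ccccc1NS(=O)(=O)c1cccc(Cl)c1)c1cccc(Cl)c1`, gives 5700 nM

Compound 1 and compound 2 share a core and differ in one place only: methyl in place of hydrogen on an aromatic carbon. This change made a step of a 1.0-fold higher number from compound 1 to compound 2 (0.01 log units; within the scatter), so the two values are indistinguishable within the usual scatter of this assay.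

Compound 3 is built from the same atoms as compound 1, joined differently; the difference between the two cores is not broken down here. What the numbers show is that compound 3 has the lowest value of the three, with compound 1 and compound 2 both clearly higher, beyond the scatter.

Compound 4, `Cc1ccc(NS(=O)(=O)c2cccc(Cl)c2)c(NS(=O)(=O)c2cccc(Cl)c2)c1`, has not yet been measured. It stands to compound 3 as compound 2 stands to compound 1: methyl in place of hydrogen on an aromatic carbon. Within the data shown here, this is the same change as the one from compound 1 to compound 2, made on the core of compound 3 instead. Since that earlier change produced a step of a 1.0-fold higher number from compound 1 to compound 2 (0.01 log units; within the scatter), the expectation is that the step from compound 3 to compound 4 will likewise be small, about a 1.1-fold higher number from compound 3 to compound 4 (0.02 log units; within the scatter), with compound 3 and its value of 5700 nM as the anchor. On this basis compound 4 is estimated to give about 6000 nM in this assay, most likely somewhere between 3000 nM and 12000 nM.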

Compound 4, half-maximal inhibitory concentration: 4300 nM
Compound 4: middle estimate off by 1.4-fold (0.14 log units), on the high side; measured number inside the range.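

Methyl in place of hydrogen on an aromatic carbon gives a 1.3-fold lower number from compound 3 to compound 4 (0.12 log units; within the scatter) in this assay and so leaves two values that cannot be told apart. Set beside the earlier pair, the same change gives a small step on both cores, and the two steps do not differ from each other in any way that can be read: the same change on two cores in this assay, a 1.0-fold higher number (0.01 log units; within the scatter) from compound 1 to compound 2 and a 1.3-fold lower number (0.12 log units; within the scatter) from compound 3 to compound 4, 1.4-fold (0.14 log units) apart, within the scatter of two such steps. This supports carrying the change from one core to the other in this series as a step too small to read, but it rests on two pairs only, and it does not show that the methyl has no effect at all, since a small true effect could be hidden in the scatter, nor that the same would hold on a core not shown here.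

The compounds shown leave open what an ethyl group, a longer chain, an amine or a carboxylic acid would do in place of this methyl. They also leave open whether a methyl on another carbon of the same ring would give an equally small step on these two cores.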